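Cytotoxicity series, biaryl amide acids: outlook for compound 4

The source may hold more compounds than are shown below. What is called first, only, known or untested is meant among the compounds shown, and "the series" means these compounds.

Measured so far in an ADME assay on HepG2 cells (Homo sapiens) for cytotoxicity, read by CellTiter-Glo and resazurin assay, with a stated time of 72 h; a lower number here means that less compound is needed, a higher number that more compound is needed for the effect:
compound 1 `CC(C)N(Cc1cccc(OCCCCCC(=O)O)c1)C(=O)c1ccc(-c2cccc(N(C)C)c2)cc1`: > 26000 nM, a limit of the assay
compound 2 `CC(C)COc1cccc(-c2ccc(C(=O)N(Cc3cccc(OCCCCCC(=O)O)c3)C(C)C)cc2)c1`: > 26000 nM, a limit of the assay
compound 3 `CC(C)N(Cc1cccc(OCCCCCC(=O)O)c1)C(=O)c1ccc(-c2ccsc2)cc1`: > 26000 nM, a limit of the assay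

Among the measured compounds shown here, compound 3 stands at a limit in this assay, and the two other values shown are limits as well; no compound in the set has a number. The steps between them are therefore not readable: a step that the two limits leave unreadable from compound 1 to compound 2, a step that the two limits leave unreadable from compound 1 to compound 3 and a step that the two limits leave unreadable from compound 2 to compound 3. For the measured compounds named here, the only evidence on the measured steps is the limit of > 26000 nM in this assay, at which 3 of the 3 values shown sit.

The next compound, compound 4 `COc1cccc(-c2ccc(C(=O)N(Cc3cccc(OCCCCCC(=O)O)c3)C(C)C)cc2)c1`, differs from compound 3 by 3-methoxyphenyl in place of thiophen-3-yl on an aromatic carbon. Compound 2 and compound 1 carry a substituted phenyl at the same place, and both sit at the limit, so no step in either direction is readable for this kind of change. For compound 4 the expected value is 30000 nM, with a range from 18000 nM to 80000 nM, most probably again only a limit. The step this estimate means, a step that the limit leaves unreadable from compound 3 to compound 4, is expected to remain unreadable in this assay.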

Compound 4, half-maximal effective concentration: > 26000 nM
Compound 4 was reported as a limit; the forecaster's own chance of this, stated with the estimate: 85%; the middle value is on the limit's open side.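

In this assay compound 4 gives > 26000 nM, a limit of the assay. Its steps to compound 1, compound 2 and compound 3 cannot be read. The compounds shown leave open at what concentration any of them affects the cells, since all share one limit: the limit of > 26000 nM in this assay, at which 4 of the 4 values shown sit.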